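The compounds below may be only part of what the source reports. "The series", "measured", "known", "first", "only" and "open" are said of these compounds alone.

Going by the values given here, in a functional assay on 2008 cells (Homo sapiens) for inhibition (a higher number here means a weaker inhibitor of growth, a lower number a stronger inhibitor of growth), compound 1 (`C=C/C=C\[C@H](C)[C@H](OC(N)=O)[C@@H](C)[C@H](O)CC/C=C\C(C)[C@@H](O)[C@@H](C)/C=C\CC[C@@H]1O[C@@H](OC)[C@H](C)[C@@H](OCOC)[C@@H]1C`) gives 4.7 nM and so holds the only true number available. Compound 2 (`COCOC1=C(C)C(=O)O[C@@H](CC/C=C\[C@H](C)[C@H](O)C(C)/C=C\CC[C@@H](O)[C@H](C)[C@@H](OC(N)=O)C(C)C)[C@H]1C`) is recorded only as a limit (> 50 nM) and not as a number. Compound 3 (`CCCCCC(C)(C)[C@H](OC(N)=O)[C@@H](C)[C@H](O)CC/C=C\C(C)[C@@H](O)[C@@H](C)/C=C\CC[C@@H]1O[C@@H](OC)[C@H](C)[C@@H](OCOC)[C@@H]1C`) has yet to be measured. It differs from compound 1 in one place, on a saturated chain carbon bound to an oxygen next to a carbonyl group and a saturated chain carbon. There the 1-methylpenta-2,4-dien-1-yl group, with its 2 double bonds, gives way to a group of 8 carbon atoms with no ring (a group of 8 heavy atoms (8 carbon; no ring) in place of a group of 6 heavy atoms (6 carbon; no ring), on a saturated chain carbon bound to an oxygen next to a carbonyl group and a saturated chain carbon). Among the compounds with values here, no measured pair of compounds tests a change at this place, so any expectation remains cautious. It starts from compound 1 at 4.7 nM in this assay as the sole numerical anchor. Weaker growth inhibition is expected, an estimated step (an 8.5-fold higher number from compound 1 to compound 3 (0.93 log units; beyond the scatter)) that would lie beyond the usual scatter. Compound 3 is estimated in this assay at 40 nM with a range from 10 nM to 200 nM as the expected bounds.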

Compound 3, concentration for 50% growth inhibition: 42 nM
Estimate against measurement, compound 3: 1.1-fold (0.02 log units) below; the measured number falls inside the stated range.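

In this assay, the saturated chain carbon bound to an oxygen next to a carbonyl group and a saturated chain carbon now has its first measured change: putting a group of 8 carbon atoms with no ring in place of the 1-methylpenta-2,4-dien-1-yl group, with its 2 double bonds, gives an 8.9-fold higher number from compound 1 to compound 3 (0.95 log units; beyond the scatter). The position is therefore not indifferent to the group it carries, although growth inhibition with the new group is still recorded as a true number rather than a limit. Compound 2 is recorded only as a limit, not a number, and says nothing about this position: the limit of > 50 nM in this assay, at which 1 of the 3 values shown sits.

This single step does not separate the loss of the 2 double bonds from the change from 6 to 8 carbon atoms, as the two change together. On these data alone, how a shorter saturated chain or a phenyl ring at this place would read against compound 1 remains open, as does whether any group here can match or improve on the 1-methylpenta-2,4-dien-1-yl group.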